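Thiocarbonyl ring swap in the amidine-thiosemicarbazide series

The source may hold more compounds than are shown below. What is called first, only, known or untested is meant among the compounds shown, and "the series" means these compounds.

Compound 1 `Cc1cccc(/C(N)=N/NC(=S)N2CCCC2)n1` is tested in a functional assay on A-375 cells (Homo sapiens) for cytotoxicity, read by MTT assay, with a stated time of 72 h, tested at 10 uM (a higher number here means more inhibition of growth at the concentration tested, a lower number less inhibition of growth), and gives 55.9%. Among the three measured compounds this is the lowest number: compound 2 `N/C(=N\NC(=S)N1CCCC1)c1ccccn1` gives 83.9%, and compound 3 `N/C(=N\NC(=S)N1CCCCCC1)c1ccc(F)cn1` gives 72.2%. Going by the values given here, the only single-point step measured so far is a number 28 percentage points higher from compound 1 to compound 2 (beyond the scatter), and it concerns the aromatic carbon, not the ring on the thiocarbonyl carbon. Compound 3 carries a larger ring on that carbon than compound 1, but it also differs elsewhere, so its number and that of compound 1 show only that the two together lie some way apart, without isolating the ring change.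

Compound 4 `Cc1cccc(/C(N)=N/NC(=S)N2CCSCC2)n1` keeps the core of compound 1 and differs from it in one place: thiomorpholin-4-yl in place of pyrrolidin-1-yl on a thiocarbonyl carbon. Among the compounds with values here, no measured step bears directly on this change. With nothing in the series pointing either way, the expected step in this assay is none beyond the scatter, with some allowance for a modest move in either direction.

Compound 4 is therefore expected to give about 58% in this assay, within 42% to 74%, an estimated step of a number 2.1 percentage points higher from compound 1 to compound 4 (within the scatter).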

Compound 4, percent growth inhibition at one concentration: 62.6%
Compound 4: middle estimate off by 4.6 percentage points, on the low side; measured number inside the range.
By their numbers in this assay, from the lowest: compounds 1, 4 and 3 (each within the scatter of the next, the first and the last beyond it); then compound 2.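

In this assay, going by these compounds alone, the only step measured on the thiocarbonyl carbon is a number 6.7 percentage points higher from compound 1 to compound 4 (within the scatter), so on the core of compound 1 this ring swap gives no separable change in growth inhibition. At this position, the read-out therefore does not distinguish thiomorpholin-4-yl, a six-membered non-aromatic ring with 2 hetero atoms, from pyrrolidin-1-yl, a five-membered non-aromatic ring with 1 hetero atom, whereas the step on the aromatic carbon, a number 28 percentage points higher from compound 1 to compound 2 (beyond the scatter), does stand clear of the scatter. No measurement is available that would account for the outcome of this swap.

On these data alone, whether the thiomorpholin-4-yl swap would also stay within the scatter on the core of compound 2, which has hydrogen in place of methyl on the aromatic carbon, remains open, and the larger ring of compound 3 is still not separated from its other differences. Also open, as far as these compounds go, is how morpholin-4-yl, piperazin-1-yl or an open-chain dimethylamino group on the thiocarbonyl carbon would read in this assay on this core.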